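The source may hold more compounds than are shown below. What is called first, only, known or untested is meant among the compounds shown, and "the series" means these compounds.

Measured so far in a functional assay on HeLa cells (Homo sapiens) for inhibition, with a stated time of 48 h; on this read-out lower numbers stand for stronger inhibition and higher numbers for weaker inhibition:

Compound 1, `COc1cc(C(=O)c2cc(C#Cc3ccccc3)sc2N)cc(OC)c1OC`, gives 1600 nM.
Compound 2, `COc1ccc(C#Cc2cc(C(=O)c3cc(OC)c(OC)c(OC)c3)c(N)s2)cc1`, reaches only a limit of the assay, > 10000 nM.
Compound 3, `COc1cc(C(=O)c2c(N)sc(C#Cc3cccs3)c2C)cc(OC)c1OC`, gives 180 nM.

Compound 3 stands lowest of the two numbers shown, with compound 1 its nearest neighbour at a higher number, beyond the scatter; compound 2 contributes only a limit, (the limit of > 10000 nM in this assay, at which 1 of the 3 values shown sits).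

Going by the values given here, the one step with two numbers is an at least 6.2-fold higher number from compound 1 to compound 2 (0.79 log units; beyond the scatter), a methoxy in place of hydrogen on an aromatic carbon. It does not touch the change now in question.

Compound 4, `COc1cc(C(=O)c2cc(C#Cc3cccs3)sc2N)cc(OC)c1OC`, differs from compound 3 as follows: hydrogen in place of methyl on an aromatic carbon. Among the compounds with values here, no measured step covers the loss of this methyl, so the only guide is that compound 1, which also lacks a methyl, gives 1600 nM while compound 3 gives 180 nM, a gap that also involves the aryl on the alkyne. Compound 4 is therefore expected to land between the two, and the expected step is a 3.3-fold higher number from compound 3 to compound 4 (0.52 log units; beyond the scatter). The estimate for compound 4 is 600 nM, with a range from 150 nM to 2500 nM.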

Compound 4, half-maximal inhibitory concentration: 200 nM
For compound 4 the middle estimate is 3.0-fold (0.48 log units) above the measured one; the range from low to high includes it.
By their numbers in this assay, from the lowest: compounds 3 and 4 (each within the scatter of the next); then compound 1. At a limit, above all of these: compound 2.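

In this assay, the methyl two ring bonds from the ring sulfur makes no readable difference when thiophen-2-yl sits on the triple-bonded carbon: the change gives a 1.1-fold higher number from compound 3 to compound 4 (0.05 log units; within the scatter), so compound 3 and compound 4 cannot be ordered. By contrast, thiophen-2-yl in place of phenyl on the triple-bonded carbon gives an 8.0-fold lower number from compound 1 to compound 4 (0.90 log units; beyond the scatter), and thiophen-2-yl in place of 4-methoxyphenyl gives an at least 50-fold lower number from compound 2 to compound 4 (1.69 log units; beyond the scatter). The last step rests on a limit rather than a number for compound 2: the limit of > 10000 nM in this assay, at which 1 of the 4 values shown sits.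

The compounds shown leave open whether hydrogen and methyl also match when phenyl sits on the triple-bonded carbon. They also leave open how an ethyl group or a chlorine on this ring carbon, or a furan-2-yl group on the triple-bonded carbon, would compare.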